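A few compounds are considered here, and "the series" means these few. Any claim that something is new, unique, unknown or untested is made for them only; others in the source may bear on it.

Compound 3 `CC(C(=O)NCc1ccc(C(F)(F)F)nc1N1CCC(c2ccccc2)CC1)c1ccc(NS(C)(=O)=O)c(F)c1` is the lowest of the two numbers available in a functional assay on CHO-K1 cells for antagonist activity at transient receptor potential cation channel subfamily V member 1 (Homo sapiens), read by FLIPR (on this read-out lower numbers stand for stronger inhibition and higher numbers for weaker inhibition), where it gives 0.6 nM. Its nearest neighbour is compound 1 `CC(C(=O)NCc1ccc(C(F)(F)F)nc1NCc1ccc(Cl)cc1)c1ccc(NS(C)(=O)=O)c(F)c1`, which in this assay gives 65.7 nM; compound 2 `CC(C(=O)NCc1ccc(C(F)(F)F)nc1NCc1cccnc1)c1ccc(NS(C)(=O)=O)c(F)c1` is reported in this assay as "not active" (no number reported). The change to compound 4 `CC(C(=O)NCc1ccc(C(F)(F)F)nc1N1CCN(C)CC1)c1ccc(NS(C)(=O)=O)c(F)c1` is 4-methylpiperazin-1-yl in place of 4-phenylpiperidin-1-yl on an aromatic carbon. Among the measured compounds shown here, the one measured step that bears on it is a 110-fold lower number from compound 1 to compound 3 (2.04 log units; beyond the scatter), and compound 2, which lacks the chlorophenyl part of compound 1, is the entry without a number. Removing the phenyl ring from compound 3 is therefore expected to raise the number by a large step, a 200-fold higher number from compound 3 to compound 4 (2.30 log units; beyond the scatter). Compound 4 is estimated in this assay at 120 nM, within 15 nM to 1000 nM.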

Compound 4, inhibition constant: 146 nM
Beside the measured number, compound 4's estimate is 1.2-fold (0.09 log units) below it; the measured number falls inside the stated range.
By their numbers in this assay, from the lowest: compound 3; then compound 1; then compound 4.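

At this carbon next to the ring nitrogen, replacing 4-phenylpiperidin-1-yl with 4-methylpiperazin-1-yl gives a 240-fold higher number from compound 3 to compound 4 (2.39 log units; beyond the scatter) in this assay, so a six-membered non-aromatic ring here does not by itself secure the low number of compound 3. Set against the (4-chlorobenzyl)amino group, the same 4-methylpiperazin-1-yl gives only a 2.2-fold higher number from compound 1 to compound 4 (0.35 log units; beyond the scatter) and thus does not reproduce the gain seen with 4-phenylpiperidin-1-yl. The compounds shown leave open whether 4-phenylpiperazin-1-yl or 4-methylpiperidin-1-yl would keep that gain, which would separate the phenyl ring from the second ring nitrogen. Nothing available gives a reason for either step.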